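The source may hold more compounds than are shown below. What is called first, only, known or untested is meant among the compounds shown, and "the series" means these compounds.

Measured so far:
- compound 1, `C[C@H](NC(=O)c1c(C#Cc2ccc(=O)[nH]c2)sc2c1CCOC2)c1ccc(C(=O)O)cc1`: 642 nM
- compound 2, `C[C@H](NC(=O)c1c(Cc2cccc(Cl)c2)sc2c1CCOC2)c1ccc(C(=O)O)cc1`: 3.2 nM
- compound 3, `C[C@H](NC(=O)c1c(NCc2ccc(C(F)(F)F)cc2)sc2c1CCOC2)c1ccc(C(=O)O)cc1`: 32.9 nM

In a functional assay on CHO/Galpha16 cells for antagonist activity at prostaglandin E2 receptor EP4 subtype (Homo sapiens), read by calcium flux, with a stated time of 15 min (a lower number here means a stronger inhibitor, a higher number a weaker inhibitor), compound 3 stands second highest of the three numbers, nearer to compound 2 than to compound 1. Compound 4, `C[C@H](NC(=O)c1c(NC(=O)c2ccc(F)cc2)sc2c1CCOC2)c1ccc(C(=O)O)cc1`, has not yet been measured. It differs from compound 3 in one place: (4-fluorophenyl)carbonyl in place of 4-(trifluoromethyl)benzyl on a nitrogen on an aromatic ring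

For the measured compounds named here, only one step between measured compounds is available, and it changes the group on an aromatic carbon of the shared core, not on the nitrogen: a 200-fold lower number from compound 1 to compound 2 (2.30 log units; beyond the scatter). It shows that what hangs on the core can shift this assay a great deal, but it does not speak directly to an exchange on the nitrogen. Compounds 2 and 3 differ in more than one place, so their values only show that the nitrogen-linked compound gives the higher number. Going by the values given here, with no guiding step, the direction of the change is open; the estimate leans toward a weaker inhibitor, expecting a 4.6-fold higher number from compound 3 to compound 4 (0.66 log units; beyond the scatter). Compound 4 is therefore expected to give 150 nM, within 20 nM to 1500 nM.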

Compound 4, half-maximal inhibitory concentration: > 1000 nM
Compound 4 ended at the assay's limit (the forecaster's own chance of this, stated with the estimate: 10%); at least 6.6-fold (0.82 log units) between middle value and limit.
By their numbers in this assay, from the lowest: compound 2; then compound 3; then compound 1. At a limit, above all of these: compound 4.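

In this assay compound 4 gives > 1000 nM as a limit of the assay and not a number. Putting (4-fluorophenyl)carbonyl in place of 4-(trifluoromethyl)benzyl on a nitrogen on an aromatic ring brings an at least 30-fold higher number from compound 3 to compound 4 (1.48 log units; beyond the scatter). Putting ((4-fluorophenyl)carbonyl)amino in place of 3-chlorobenzyl on an aromatic carbon brings an at least 310-fold higher number from compound 2 to compound 4 (2.49 log units; beyond the scatter) and both sizes are only floors: the limit of > 1000 nM in this assay, at which 1 of the 4 values shown sits.

The remaining step, an at least 1.5-fold higher number from compound 1 to compound 4 (0.19 log units; that floor lies within the scatter), leaves this pair without a firm order. Going by these compounds, it also remains open whether the carbonyl or the change on the ring drives the loss, which a 4-fluorobenzyl group on the same nitrogen could separate, while a sulfonyl group there would test another link.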